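Methyl Ester Extended by One Carbon on the Shared Core

The source may report more compounds than this note shows. Statements on the series, on what has been measured and on what is new or still open speak of the compounds shown alone.

Within the data shown here, compound 1 `COC(=O)[C@H](CCSC)NC(=O)c1ccc(CNCc2c[nH]cn2)cc1-c1ccccc1C` gives 25 uM in a functional assay on NIH3T3 cells (Mus musculus) (a lower number here means that less compound is needed, a higher number that more compound is needed for the effect), the only number among the three values shown for this series. Compound 2 `CSCC[C@H](NC(=O)c1ccc(NCc2cncn2Cc2cccc(Cl)c2)cc1-c1ccccc1)C(=O)O` sits at a limit of this assay, > 10 uM, rather than a number. Compound 3 `COC(=O)[C@H](CCSC)NC(=O)c1ccc(CN(Cc2c[nH]cn2)Cc2c[nH]cn2)cc1-c1ccccc1C` also sits at a limit, > 10 uM. The step that the limit leaves unreadable from compound 1 to compound 3 therefore cannot be read, because the limit of > 10 uM in this assay, at which 2 of the 3 values shown sit, hides its size. Compound 4 `CCOC(=O)[C@H](CCSC)NC(=O)c1ccc(CNCc2c[nH]cn2)cc1-c1ccccc1C` keeps the core of compound 1 and changes only the ester: methyl in place of hydrogen on a saturated chain carbon bound to an oxygen next to a carbonyl group. Among the measured compounds shown here, no measured step touches this position, so nothing points to a change beyond the scatter in this assay. The expected step of no change at the digits printed from compound 1 to compound 4 (within the scatter) is thus small, and compound 4 is estimated at 25 uM, within a range of 8 uM to 80 uM.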

Compound 4, concentration for half-maximal effect: 10 uM
The estimate for compound 4 lay 2.5-fold (0.40 log units) above the measured number; measured number inside the range.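

Among these compounds, the ester is the first position where a change can be sized in this assay: going from methoxycarbonyl to ethoxycarbonyl gives a 2.5-fold lower number from compound 1 to compound 4 (0.40 log units; beyond the scatter). This shows that a single added methyl at this position can shift the number by a modest step. The only earlier step, on the amine nitrogen, cannot be read: the limit of > 10 uM in this assay, at which 2 of the 4 values shown sit.

As far as these compounds go, whether a longer chain such as propyl would move the number further stays open. So does the effect of a branched isopropyl or a ring-bearing benzyl ester on this core.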